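A few compounds are considered here, and "the series" means these few. Any claim that something is new, unique, unknown or untested is made for them only; others in the source may bear on it.

Compound 1 `CC(C)(C)C#Cc1cc(N(C(=O)[C@H]2CC[C@H](C)CC2)[C@H]2CC[C@](O)(CO[C@H]3CCOC3)CC2)c(C(=O)O)s1`: > 20000 nM
Compound 2 `CC(C)(C)C#Cc1cc(N(C(=O)[C@H]2CC[C@H](C)CC2)[C@H]2CC[C@H](OC3CCOCC3)CC2)c(C(=O)O)s1`: > 20000 nM
Compound 3 `CC(C)(C)C#Cc1cc(N(C(=O)[C@H]2CC[C@H](C)CC2)[C@H]2CC[C@@H](Oc3cccnc3)CC2)c(C(=O)O)s1`: > 20000 nM

All three entries come from an ADME assay on MT4 cells (Homo sapiens) for cytotoxicity, with a stated time of 5 days (on this read-out higher numbers stand for lower toxicity in this test and lower numbers for higher toxicity in this test), and each is a limit of the assay, not a number. Among the measured compounds shown here, the series so far shows (the limit of > 20000 nM in this assay, at which 3 of the 3 values shown sit). Compound 2 therefore stands at a limit, with no measured number to place it above or below compound 1 or compound 3. For the measured compounds named here, no step between measured compounds that differ in one place is available, so the data give no direct size for a single change.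

The next compound to follow is compound 4 `CC(C)(C)C#Cc1cc(N(C(=O)[C@H]2CC[C@H](C)CC2)[C@H]2CC[C@H](Oc3nccs3)CC2)c(C(=O)O)s1`. It carries 1,3-thiazol-2-yl in place of the oxan-4-yl of compound 2, on an oxygen on a saturated carbon: 1,3-thiazol-2-yl in place of oxan-4-yl on an oxygen on a saturated carbon.

Compound 3, which has an aromatic group on its ether oxygen, also gives a limit, > 20000 nM. On that basis, no step beyond the scatter is expected in this assay, in either direction. The expected change is a number no higher from compound 2 to compound 4 (the limit leaves the size open). A report of compound 4 as a limit only would be the likeliest outcome. The estimate for compound 4 is 20000 nM, with an expected range of 10000 nM to 40000 nM.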

Compound 4, half-maximal cytotoxic concentration: > 20000 nM
Compound 4: a limit, no number (the forecaster's own chance of this, stated with the estimate: 80%); the middle value sits exactly at the limit.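

Among the compounds shown here, compound 2 and compound 4 both stand at a limit in this assay, not at a number, so no step between them can be read. The compounds shown leave open where any of them would fall as a measured number, and whether any change on the shared core would yield one: the limit of > 20000 nM in this assay, at which 4 of the 4 values shown sit.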